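Replacing 4-nitrophenyl with 2-methylphenyl on the shared core

The source may hold more compounds than are shown below. What is called first, only, known or untested is meant among the compounds shown, and "the series" means these compounds.

In a functional assay on PC-3 cells (Homo sapiens) for cytotoxicity, read by sulforhodamine B assay, with a stated time of 48 h (on this read-out higher numbers stand for weaker inhibition and lower numbers for stronger inhibition), compound 1 `C[C@H]1CC[C@@H]2[C@@H](OC(=O)[C@]23CC(c2ccccc2)=NO3)[C@]2(C)C(=O)C=C[C@@]12O` gives 46000 nM as its reading. Compound 2 `C[C@H]1CC[C@@H]2[C@@H](OC(=O)[C@]23CC(c2ccc(O)cc2)=NO3)[C@]2(C)C(=O)C=C[C@@]12O` gives 20000 nM on the same read-out, and compound 3 `C[C@H]1CC[C@@H]2[C@@H](OC(=O)[C@]23CC(c2ccc([N+](=O)[O-])cc2)=NO3)[C@]2(C)C(=O)C=C[C@@]12O` gives 12000 nM on it too. Compound 3 shares the low end of this short series with compound 2: the gap between them is a 1.7-fold lower number from compound 2 to compound 3 (0.22 log units; within the scatter) and no order can be read from it.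

Compound 4 `Cc1ccccc1C1=NO[C@]2(C1)C(=O)O[C@@H]1[C@H]2CC[C@H](C)[C@]2(O)C=CC(=O)[C@@]12C` comes next, with 2-methylphenyl in place of 4-nitrophenyl on a carbon with a double bond to nitrogen in the shared core. For the measured compounds named here, two measured steps bear on this change, both starting from the plain phenyl ring: a 2.3-fold lower number from compound 1 to compound 2 (0.36 log units; beyond the scatter) and a 3.8-fold lower number from compound 1 to compound 3 (0.58 log units; beyond the scatter) are both modest. Going by the values given here, no measured compound carries a methyl on this ring, so no step shows directly what the entering group does. Compound 4 lacks the nitro of compound 3, so a number drifting back toward compound 1 at 46000 nM is expected in this assay as a modest step upward. The expected step is a 2.5-fold higher number from compound 3 to compound 4 (0.40 log units; beyond the scatter) and it stays modest in size. For compound 4 the estimated value is 30000 nM with an expected range from 12000 nM to 70000 nM overall.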

Compound 4, half-maximal inhibitory concentration: 10000 nM
The estimate for compound 4 lay 3.0-fold (0.48 log units) above the measured number; measured number outside the range, below it.
By their numbers in this assay, from the lowest: compounds 4, 3 and 2 (each within the scatter of the next); then compound 1.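

In this assay, swapping 4-nitrophenyl for 2-methylphenyl gives a 1.2-fold lower number from compound 3 to compound 4 (0.08 log units; within the scatter), and swapping 4-hydroxyphenyl for 2-methylphenyl gives a 2.0-fold lower number from compound 2 to compound 4 (0.30 log units; within the scatter), so no order can be read among these three rings. Against the plain phenyl ring, adding a methyl gives a 4.6-fold lower number from compound 1 to compound 4 (0.66 log units; beyond the scatter), a modest step beyond the scatter in the same direction as the hydroxy and nitro steps, and no compound shown goes against that direction. The lower numbers at this position therefore do not depend on the nitro or hydroxy group: a ring carrying only a methyl reaches the same range, although all of these readings remain modest changes from compound 1.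

Nothing available explains why the three substituted rings fall together. Still open, from the compounds shown here alone, is whether an amine, a carboxylic acid or a longer chain such as ethyl on this ring would stay in the same range or move the number further from that of compound 1.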